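Methyl on the oxadiazole of compound 2: an expected small step

The source may report more compounds than this note shows. Statements on the series, on what has been measured and on what is new or still open speak of the compounds shown alone.

Measured compounds:
compound 1, `C=CCc1c(OC)nc2nc(-c3noc(C)n3)cn2c1C`, 10 mg/kg
compound 2, `CCc1c(OC)nc2nc(-c3nnco3)cn2c1C`, > 50 mg/kg

In a functional assay on the whole organism with Rattus norvegicus as the target (on this read-out lower numbers stand for an effect already at smaller amounts and higher numbers for an effect only at larger amounts of compound), compound 1 gives 10 mg/kg. Compound 2, `CCc1c(OC)nc2nc(-c3nnco3)cn2c1C`, reaches only a limit of the assay in this assay, > 50 mg/kg, so for compound 2 no number is known, only (the limit of > 50 mg/kg in this assay, at which 1 of the 2 values shown sits). Within the data shown here, the two compounds differ in more than one place, and no single step between them is known; their values show only that compound 1 has a number where compound 2 has a limit.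

Compound 3, `CCc1c(OC)nc2nc(-c3nnc(C)o3)cn2c1C`, is not yet measured. It differs from compound 2 by methyl in place of hydrogen on an aromatic carbon. This is a small change, and with the parent sitting at a limit, no clear direction can be drawn from the shown data. The step that the limit leaves unreadable from compound 2 to compound 3 is expected to stay within the usual scatter, and compound 3 is estimated at 60 mg/kg, with a range from 20 mg/kg to 200 mg/kg.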

Compound 3, minimum effective dose: 2 mg/kg
Compound 3: the middle estimate sits 30-fold (1.48 log units) above what was measured, outside the stated range (below it).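

Placing methyl on this ring carbon, 1,3,4-oxadiazol-2-yl to 5-methyl-1,3,4-oxadiazol-2-yl, gives an at least 25-fold lower number from compound 2 to compound 3 (1.39 log units; beyond the scatter) in this assay. Among these compounds, this is the first single-place step, and it shows that the aromatic carbon next to the ring nitrogen and next to the ring oxygen is not a silent position, since a change of 1 heavy atom there moves the read-out beyond the scatter. The value of compound 2 is a limit and not a number, so the step has a known floor but no known size: the limit of > 50 mg/kg in this assay, at which 1 of the 3 values shown sits.

Methyl is the only group shown on this carbon apart from hydrogen, so it remains open whether a longer chain such as ethyl, or an amine, would give a similar result. Compound 1 differs from compound 3 in more than one place and cannot settle this.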